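A few compounds are considered here, and "the series" means these few. Any claim that something is new, unique, unknown or untested is made for them only; others in the source may bear on it.

Measured so far in a physicochemical assay for lipophilicity, read by HPLC; on this read-out lower numbers stand for lower lipophilicity and higher numbers for higher lipophilicity:

- Compound 1 `O=C1/C(=C/c2ccc(Br)cc2)C(c2ccccc2)Oc2ccccc21` gives 4.46
- Compound 2 `O=c1c(Cc2ccc([N+](=O)[O-])cc2)coc2ccccc12` gives 3.93

Of these two numbers compound 2 holds the lower one, and the gap up to compound 1 lies beyond the usual scatter of repeated measurements. These two compounds differ in more than one place, so the gap cannot be tied to any single change.

The next compound to be read is compound 3 `O=c1c(Cc2ccc(F)cc2)coc2ccccc12` which keeps the core of compound 2 and carries fluoro in place of nitro on an aromatic carbon, para to a large group fluoro in place of nitro on an aromatic carbon and nothing else is altered. Among the measured compounds shown here, no measured pair here differs in one place only, so the expectation rests on the structural change alone and remains loose.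

A small rise is expected, with an estimated a number 0.37 log units higher from compound 2 to compound 3 (beyond the scatter) that would clear the scatter only narrowly, if at all. In this assay the estimate for compound 3 is 4.3 (expected range 3.95 to 4.65).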

Compound 3, partition coefficient: 4.02
Estimate against measurement, compound 3: 0.28 log units above; measured number inside the range.
By their numbers in this assay, from the lowest: compounds 2 and 3 (each within the scatter of the next); then compound 1.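

In this assay, among the compounds shown here, fluoro in place of nitro on an aromatic carbon, para to a large group, gives a number 0.09 log units higher from compound 2 to compound 3 (within the scatter) and is the first change here that can be tied to one place. At this position on the shared core, then, a nitro group with its 3 heavy atoms and 2 hydrogen-bond acceptors can give way to a single fluoro with no hydrogen-bond acceptors, and the two compounds still cannot be told apart on this read-out. No measurement at hand bears on why the two groups read alike.

Nitro and fluoro are the only two groups compared at this position, so it remains open whether an amine, a carboxylic acid or a longer chain in the same place would also stay within the scatter of these two compounds. As far as these compounds go, it also remains open whether the same exchange would read alike on a different core, such as that of compound 1, which differs from compound 2 in more than one place and cannot be set against it.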